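The source may report more compounds than this note shows. Statements on the series, on what has been measured and on what is new or still open speak of the compounds shown alone.

Working notes on a small set of amides tested in a functional assay on cells (Platelet, Oryctolagus cuniculus) for inhibition, read by turbidimetry, with a stated time of 3 min, tested at 100 ug/mL; a higher number here means a weaker effect of the compound at the concentration tested, a lower number a stronger effect. Compound 1 `CCCCCCCCC/C=C/C=C/C(=O)NCC(C)(C)O` gives 0% in this assay. Compound 2 `C=CCCC1(CCC=C)C(=O)Nc2ccccc2C1OC` gives 0% and compound 3 `CCC(=O)CC/C=C\CC/C=C/C=C/C(=O)NCC(C)C` gives 0%; compound 1 stands level with both at the digits shown, nearest to compound 2 and furthest from compound 3, in each case with no change beyond the scatter. No pair among these three differs in a single place, so no step within the measured set can be read off.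

Compound 4 `CC/C=C\C/C=C\CC/C=C/C=C/C(=O)NCC(C)(C)O` is not yet measured. The difference from compound 1 is hepta-1,4-dien-1-yl in place of heptyl on a saturated chain carbon, two bonds along the chain from a double-bonded chain carbon. Compound 3, also an unsaturated amide, gives 0% in this assay, so no step beyond the scatter is expected from the change in the chain. The step expected in this assay is no change at the digits printed from compound 1 to compound 4 (within the scatter), in no particular direction. For compound 4 the estimate in this assay is 0%, with a range from 0% to 15%.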

Compound 4, a percentage reported as activity, at one concentration (the size of the read-out at that concentration, not a potency): 0%
The estimate for compound 4 equals the measured number at the digits printed; the measured number falls inside the stated range.
By their numbers in this assay, from the lowest: compounds 1, 2, 3 and 4 (each within the scatter of the next).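

In this assay, for the compounds shown here, hepta-1,4-dien-1-yl in place of heptyl on a saturated chain carbon, two bonds along the chain from a double-bonded chain carbon, gives no change at the digits printed from compound 1 to compound 4 (within the scatter), the first step in this set that can be read at a single place. With the rest of compound 1 kept, the two double bonds brought in by this group leave the read-out level at the tested concentration. Nothing measured here accounts for this result.

What the compounds shown leave open is whether any change at this place can move the read-out, since this one step shows no movement. As far as these compounds go, whether a longer chain, or an amine or a carboxylic acid carried on the chain, would read differently from compound 1 also stays open.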